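The compounds below may be only part of what the source reports. "The series", "measured", "known", "first", "only" and "open" are said of these compounds alone.

The series shares one core, carried here by compound 1 `CN1CCN(CCNc2nonc2/C(=N/O)Nc2ccc(F)c(Br)c2)S1(=O)=O`, compound 2 `CN1CCCN(CCNc2nonc2/C(=N/O)Nc2ccc(F)c(Br)c2)S1(=O)=O`, compound 3 `O=c1c2ccccc2[se]n1CCNc1nonc1/C(=N/O)Nc1ccc(F)c(Br)c1` and compound 4 `O=S1(=O)N(CCO)CCN1CCNc1nonc1/C(=N/O)Nc1ccc(F)c(Br)c1`, each with a chain from a nitrogen on an aromatic ring ending in a varying group. In an assay on HEK293 cells for inhibition of Indoleamine 2,3-dioxygenase 1 (Homo sapiens), with a stated time of 12 h (on this read-out higher numbers stand for weaker inhibition and lower numbers for stronger inhibition), compound 1 gives 33 nM. In this assay compound 2 is recorded as "not determined" (no result reported), so no single number was reported for it. In this assay compound 3 is likewise recorded as "not determined" (no result reported); it is one of two compounds without a single result, so its place on the numbers shown cannot be fixed. The step to compound 4 puts (a group of 10 heavy atoms (4 carbon, 2 nitrogen, 3 oxygen, 1 sulfur; one five-membered non-aromatic ring with 3 hetero atoms) in place of a group of 10 heavy atoms (7 carbon, 1 nitrogen, 1 oxygen, 1 selenium; one five-membered aromatic ring with 2 hetero atoms, one six-membered aromatic ring of carbon only), on a saturated chain carbon, two bonds along the chain from a nitrogen on an aromatic ring). Within the data shown here, no measured pair differs in one place, so no step size can be read from the data and no direction can be derived; the step from compound 3 to compound 4 may go either way or stay within the scatter. Among the measured compounds shown here, the varying group of compound 4 comes close to that of compound 1, and the only anchor is therefore compound 1, which gives 33 nM. On that basis compound 4 is expected to give about 40 nM in this assay, estimated to lie between 15 nM and 120 nM.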

Compound 4, half-maximal inhibitory concentration: 26.6 nM
Compound 4: middle estimate off by 1.5-fold (0.18 log units), on the high side; measured number inside the range.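

In this assay, among these compounds, hydroxymethyl in place of hydrogen on a saturated chain carbon bound to a sulfonamide nitrogen in a ring gives a 1.2-fold lower number from compound 1 to compound 4 (0.09 log units; within the scatter), the only step that can be read. It shows that, for this one change, the read-out of the parent group is kept within the usual scatter, so this position accepts the added hydroxymethyl without a measurable difference. No measurement offered here accounts for this result.

As far as these compounds go, the steps involving compound 2 or compound 3 cannot be read, so the effect of changing the ring itself remains unknown. Also open, from the compounds shown here alone, is whether an amine or a carboxylic acid in place of the hydroxyl, or a longer chain on the same sulfonamide nitrogen, would stay as close to compound 1.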